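A few compounds are considered here, and "the series" means these few. Any claim that something is new, unique, unknown or untested is made for them only; others in the source may bear on it.

Compound 3, `O=C(COc1cccc2ccccc12)N/N=C/c1ccccc1`, gives 64.5 ug/mL in an ADME assay on HEL cells (Homo sapiens) for cytotoxicity; on this read-out higher numbers stand for lower toxicity in this test and lower numbers for higher toxicity in this test. Among the three compounds measured so far it stands second highest, yet every gap around it falls within the scatter: compound 1, `O=C(COc1cccc2ccccc12)N/N=C/c1ccccc1Br`, gives 100 ug/mL, and compound 2, `O=C(COc1cccc2ccccc12)N/N=C/c1ccccc1Cl`, gives 62.7 ug/mL. The three differ only in what sits on the aromatic carbon of the benzylidene ring, and none of those exchanges moved the number beyond the scatter: a 1.6-fold lower number from compound 1 to compound 2 (0.20 log units; within the scatter), a 1.6-fold lower number from compound 1 to compound 3 (0.19 log units; within the scatter) and a 1.0-fold higher number from compound 2 to compound 3 (0.01 log units; within the scatter).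

Compound 4, `O=C(COc1cccc2ccccc12)N/N=C/c1ccc(F)cc1`, is the next step from compound 3. The change is fluoro in place of hydrogen on an aromatic carbon. The measured steps that bear on it are the halogen exchanges on the same six-membered ring, all of which stayed within the scatter; the fluoro now enters at a different place on that ring, so the carry-over is only approximate. Still, with three halogen steps all within the scatter, no step beyond the scatter is expected in this assay. The estimate for compound 4 is therefore 65 ug/mL, between 40 ug/mL and 105 ug/mL, which means a step of a 1.0-fold higher number from compound 3 to compound 4 (0.00 log units; within the scatter) is expected.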

Compound 4, half-maximal cytotoxic concentration: 71.6 ug/mL
The estimate for compound 4 lay 1.1-fold (0.04 log units) below the measured number; low and high end bracket the measured number.
By their numbers in this assay, from the lowest: compounds 2, 3, 4 and 1 (each within the scatter of the next).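

In this assay, fluoro in place of hydrogen, para to a large group on the six-membered aromatic ring, gives a step that stays within the scatter (a 1.1-fold higher number from compound 3 to compound 4 (0.05 log units; within the scatter)), so a halogen at this place on the ring moves the number no more than the halogen exchanges among compounds 1, 2 and 3 did. The comparisons with the two other halogen compounds change both the halogen and its place on the ring, and they too stay within the scatter (a 1.1-fold higher number from compound 2 to compound 4 (0.06 log units; within the scatter); a 1.4-fold lower number from compound 1 to compound 4 (0.15 log units; within the scatter)), which leaves all four compounds unseparated in this assay. Nothing available here accounts for these numbers staying so close.

The compounds shown carry only hydrogen or a single halogen on this ring, so what an amine or a carboxylic acid at this place would do to the number stays open. As far as these compounds go, all four also share the rest of the structure, so whether the number responds to a change outside this ring, such as a longer chain in the linker, is equally open.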